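This account rests on a few compounds, and the source may have more. Where it says the series, first, only, none or still open, it means among the compounds named here.

Of the compounds shown here, three with a shared core have been measured in a functional assay on MT4 cells (Homo sapiens) for cytotoxicity, read by MTT assay; a higher number here means that more compound is tolerated, a lower number that less compound is tolerated. Compound 1 `Cc1c(O)nc(SCc2ccc(Cl)cc2)nc1Cc1c(Cl)cccc1Cl` gives > 59000 nM, and this is a limit of the assay, not a number. Compound 2 `Cc1c(O)nc(SCc2ccc(C#N)cc2)nc1Cc1c(F)cccc1F` gives > 65000 nM, which is also a limit. Compound 3 `COc1ccc(CSc2nc(O)c(C)c(Cc3ccc(F)cc3)n2)cc1` gives a true number, 8900 nM, so less of it is tolerated than of the other two. From the compounds shown here alone, compound 1 therefore stands with compound 2 on the well-tolerated side of this small set, and its exact value is unknown.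

Compound 4 `CCCCOc1ccc(CSc2nc(O)c(C)c(Cc3c(Cl)cccc3Cl)n2)cc1` keeps the rest of compound 1 and changes one group: butoxy in place of chloro on an aromatic carbon. Butoxy replaces chloro on an aromatic carbon, para to a large group. Among the compounds with values here, no measured pair isolates this change, so any forecast is loose. The nearest guide is compound 3, which carries a methoxy group and gives 8900 nM, although it also differs from compound 1 elsewhere. A moderate drop in the tolerated concentration is expected, with a real chance that compound 4 again returns only a limit. The expected change is an at least 2.9-fold lower number from compound 1 to compound 4 (0.46 log units; beyond the scatter). For compound 4 the estimated value is 20000 nM, with an expected range from 6000 nM to 65000 nM.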

Compound 4, half-maximal cytotoxic concentration: 3100 nM
Beside the measured number, compound 4's estimate is 6.5-fold (0.81 log units) above it; the measured number lies below the stated range.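

In this assay, replacing chloro with butoxy on an aromatic carbon, para to a large group, gives an at least 19-fold lower number from compound 1 to compound 4 (1.27 log units; beyond the scatter). Within the data shown here, this is the first step in the set that changes one place only, so it ties a clear fall in the tolerated concentration to this position, and it shows that the fall is large rather than moderate, although its exact size stays unknown. Compound 1 gives > 59000 nM, and this is a limit of the assay, so the step is a minimum: the limit of > 59000 nM in this assay, at which 1 of the 4 values shown sits.

The compounds shown leave open whether the fall belongs to the butoxy chain itself or would also appear with a shorter chain such as methoxy or ethoxy, or with a longer one such as hexyloxy, on the rest of compound 1. Also open, from the compounds shown here alone, is how an amine or a carboxylic acid would behave at this position, and whether butoxy would bring a fall of similar size in a compound that differs elsewhere, such as compound 2 or compound 3.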